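One Methyl on the Phenylsulfonyl Group of Compound 3

The compounds below may be only part of what the source reports. "The series", "measured", "known", "first", "only" and "open" are said of these compounds alone.

In a functional assay on PC-3 cells (Homo sapiens) for cytotoxicity, read by MTT assay, with a stated time of 72 h (a lower number here means a stronger inhibitor, a higher number a weaker inhibitor), compound 1 `O=S(=O)(c1ccccc1)c1nc2ccccc2nc1Nc1ccccc1` gives 590 nM. Placing 3,5-dimethoxyphenyl in place of phenyl on the nitrogen gives compound 2 `COc1cc(Nc2nc3ccccc3nc2S(=O)(=O)c2ccccc2)cc(OC)c1` at 140 nM, which is a 4.2-fold lower number from compound 1 to compound 2 (0.62 log units; beyond the scatter). One more methoxy in place of hydrogen on an aromatic carbon gives compound 3 `COc1cc(Nc2nc3ccccc3nc2S(=O)(=O)c2ccccc2)cc(OC)c1OC` at 29100 nM, which is a 210-fold higher number from compound 2 to compound 3 (2.32 log units; beyond the scatter). That is the highest number of the three, so compound 3 is the weakest inhibitor measured so far.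

Compound 4 `COc1cc(Nc2nc3ccccc3nc2S(=O)(=O)c2ccc(C)cc2)cc(OC)c1OC` keeps everything in compound 3 except the phenylsulfonyl group, which becomes (4-methylphenyl)sulfonyl: methyl in place of hydrogen on an aromatic carbon. In words, this is methyl in place of hydrogen on an aromatic carbon, para to a large group.

Neither measured step changed this group, since both lie in the group on the nitrogen. The data therefore give no direct guide to direction or size here. Still, a 210-fold higher number from compound 2 to compound 3 (2.32 log units; beyond the scatter) came from one added group, so a wide range is sensible. The expected result is no change beyond the scatter, with a 1.5-fold lower number from compound 3 to compound 4 (0.16 log units; within the scatter) as the estimate. Compound 4 is expected at 20000 nM, with an estimated range of 4000 nM to 60000 nM.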

Compound 4, half-maximal inhibitory concentration: 4850 nM
The estimate for compound 4 lay 4.1-fold (0.62 log units) above the measured number; the range from low to high includes it.
By their numbers in this assay, from the lowest: compound 2; then compound 1; then compound 4; then compound 3.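

In this assay, for the compounds shown here, this is the first sign that the phenylsulfonyl group can change the result, since every earlier step lay in the group on the nitrogen: methyl in place of hydrogen on an aromatic carbon, para to a large group, gives a 6.0-fold lower number from compound 3 to compound 4 (0.78 log units; beyond the scatter). A single added carbon at this position therefore moves the number beyond the scatter, although this modest step is far from the large one seen earlier, a 210-fold higher number from compound 2 to compound 3 (2.32 log units; beyond the scatter). No measurement here explains why the number falls with this methyl, so the reason remains unknown.

The methyl step is shown only on compound 3, so it remains open whether the same change would lower the number by a similar amount on compound 1 or compound 2, where the group on the nitrogen is different. On these data alone, it is also open what a longer chain such as ethyl, a chlorine atom, an amine or a carboxylic acid would do in this same place on the ring, and so whether the gain is particular to methyl or extends to other groups.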